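The source may report more compounds than this note shows. Statements on the series, on what has been measured and on what is new or still open speak of the compounds shown alone.

Measured so far:
Compound 1, `C[Se]c1c(SCC#CCO)cnc2ccccc12`, gives 5.8 ug/mL in a functional assay on B16 cells (Mus musculus) for cytotoxicity, read by sulforhodamine B assay, with a stated time of 72 h; on this read-out lower numbers stand for stronger inhibition and higher numbers for weaker inhibition.
Compound 2, `C#CC[Se]c1c(SCC#CCO)cnc2ccccc12`, gives 6.8 ug/mL.
Compound 3, `C#CCSc1cnc2ccccc2c1[Se]CC#CCO`, gives 3.6 ug/mL.

All three numbers lie within the usual scatter of one another, so no order among them is claimed. Compound 2 and compound 3 are built from the same atoms joined differently; the difference between the two cores is not broken down here. Between compound 2 and compound 1 the change is hydrogen in place of ethynyl on a saturated chain carbon bound to a selenium atom, and the step it made was a 1.2-fold lower number from compound 2 to compound 1 (0.07 log units; within the scatter). Compound 4, `CSc1cnc2ccccc2c1[Se]CC#CCO`, has not yet been measured in this assay. It differs from compound 3 by hydrogen in place of ethynyl on a saturated chain carbon bound to a sulfur. This is the same kind of change, but the place differs: in the earlier pair the chain carbon is bound to a selenium atom, whereas here it is bound to a sulfur. Because the earlier step was a 1.2-fold lower number from compound 2 to compound 1 (0.07 log units; within the scatter), compound 4 is expected to show a similarly small step, a 1.1-fold lower number from compound 3 to compound 4 (0.04 log units; within the scatter). Compound 4 is therefore estimated at 3.3 ug/mL, with a likely range from 1.7 ug/mL to 6.5 ug/mL.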

Compound 4, concentration for 50% inhibition: 4.2 ug/mL
The estimate for compound 4 lay 1.3-fold (0.10 log units) below the measured number; low and high end bracket the measured number.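

Hydrogen in place of ethynyl on a saturated chain carbon bound to a sulfur gave a 1.2-fold higher number from compound 3 to compound 4 (0.07 log units; within the scatter) in this assay. Set beside the same change on the other core, the two steps do not differ: the same change on two cores in this assay, a 1.2-fold lower number (0.07 log units; within the scatter) from compound 2 to compound 1 and a 1.2-fold higher number (0.07 log units; within the scatter) from compound 3 to compound 4, 1.4-fold (0.14 log units) apart, within the scatter of two such steps. This shows that, in these two pairs, propargyl to methyl made no step beyond the scatter on either core, but it does not show that the change has a shared effect, since neither step can be told from the scatter, nor does it reach beyond these two cores.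

Only methyl and propargyl appear in this place among the compounds shown. From the compounds shown here alone, whether a longer chain or an amine there would give a step beyond the scatter remains open.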